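A few compounds are considered here, and "the series" means these few. Any claim that something is new, unique, unknown or untested is made for them only; others in the source may bear on it.

The measured compounds:
compound 1, `C[C@@H]1CN(c2cccc(NS(=O)(=O)c3ccc(-c4ccccn4)s3)c2)C[C@H](C)N1`, in a functional assay for agonist activity at growth hormone secretagogue receptor type 1 (Homo sapiens), read by FLIPR; a higher number here means that more compound is needed for the effect, a lower number that less compound is needed: 39.8 nM
compound 2, `COc1ccc(N2C[C@@H](C)N[C@@H](C)C2)cc1NS(=O)(=O)c1ccc(-c2ccccc2)cc1`, in this assay: 6.31 nM
compound 3, `COc1ccc(N2C[C@@H](C)N[C@@H](C)C2)cc1NS(=O)(=O)c1ccc(-c2cc(Cl)ccc2F)cc1`, in this assay: 0.501 nM

Compound 3 gives the lowest of the three numbers in this assay. Within the data shown here, its nearest neighbour is compound 2, which lies a step of a 13-fold lower number from compound 2 to compound 3 (1.10 log units; beyond the scatter) away, and compound 1 sits furthest off, with a number well above both, though compound 1 differs from the others in more than one place and no single step connects it to them.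

Compound 4, `COc1ccc(N2C[C@@H](C)N[C@@H](C)C2)cc1NS(=O)(=O)c1ccc(-n2cccn2)cc1`, differs from compound 3 in one place: 1H-pyrazol-1-yl in place of 5-chloro-2-fluorophenyl on an aromatic carbon. Among the measured compounds shown here, the only measured step at this position is the one from compound 2 to compound 3, in which a 13-fold lower number from compound 2 to compound 3 (1.10 log units; beyond the scatter) accompanied the exchange of plain phenyl for 5-chloro-2-fluorophenyl. Compound 4 gives up that halogenated phenyl for a smaller five-membered ring with two nitrogen atoms, so the gain seen in that step is not expected to carry over; a step back up toward the level of compound 2 is the most plausible outcome, though how far is uncertain.

Compound 4 is therefore expected to give about 10 nM in this assay, within a range of 2 nM to 50 nM. This estimate corresponds to an expected step of a 20-fold higher number from compound 3 to compound 4 (1.30 log units; beyond the scatter).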

Compound 4, half-maximal effective concentration: 15.9 nM
For compound 4 the middle estimate is 1.6-fold (0.20 log units) below the measured one; low and high end bracket the measured number.
By their numbers in this assay, from the lowest: compound 3; then compound 2; then compound 4; then compound 1.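

In this assay, the aromatic carbon para to a large group now carries three different rings on an otherwise shared structure, and the number moves in both directions from plain phenyl. Exchanging 5-chloro-2-fluorophenyl for 1H-pyrazol-1-yl gives a 32-fold higher number from compound 3 to compound 4 (1.50 log units; beyond the scatter) and so undoes the whole gain the halogenated phenyl had brought, while the same exchange starting from plain phenyl gives a 2.5-fold higher number from compound 2 to compound 4 (0.40 log units; beyond the scatter) as a smaller rise that still lies beyond the scatter. The pyrazole therefore does not merely lack the benefit of the halogenated ring but also stands above plain phenyl, so this position can worsen the number as well as improve it, and nothing available here explains either direction.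

Compound 4 changes ring size, heavy-atom count and ring nitrogen content in a single exchange, so the compounds shown cannot say which of these goes with the rise. Also open, as far as these compounds go, is how a pyridine ring would behave at this position on the shared structure, and whether a phenyl bearing only chlorine or only fluorine would keep the low number of compound 3.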